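Swapping 3-methylphenyl for 4-methylphenyl at the assay limit

The source may hold more compounds than are shown below. What is called first, only, known or untested is meant among the compounds shown, and "the series" means these compounds.

In a functional assay on K562 cells (Homo sapiens) for inhibition, read by trypan blue exclusion, with a stated time of 48 h (on this read-out higher numbers stand for weaker inhibition and lower numbers for stronger inhibition), compound 2 `Cc1cccc(/C=C/C(=O)Nc2ccc(Cl)cc2C(N)=O)c1` gives > 10000 nM, which is a limit and not a number. Compound 1 `NC(=O)c1cc(Cl)ccc1NC(=O)/C=C/c1cccc(Br)c1` gives > 10000 nM in this assay, and this too is a limit. Together they give (the limit of > 10000 nM in this assay, at which 2 of the 2 values shown sit). Compound 3 `Cc1ccc(/C=C/C(=O)Nc2ccc(Cl)cc2C(N)=O)cc1` has 4-methylphenyl in place of 3-methylphenyl on a double-bonded chain carbon bound to a double-bonded chain carbon. Within the data shown here, the one measured step, a step that the two limits leave unreadable from compound 1 to compound 2, has no readable size to carry over. No direction is favoured, and the expected change is a step that the limit leaves unreadable from compound 2 to compound 3, with nothing beyond the scatter expected. For compound 3 the estimated value is 12000 nM, with an expected range from 4000 nM to 40000 nM.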

Compound 3, half-maximal inhibitory concentration: 6300 nM
Compound 3: middle estimate off by 1.9-fold (0.28 log units), on the high side; the measured number falls inside the stated range.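

In this assay, among these compounds, compound 3 is the only one of the three with a number rather than a limit, so 4-methylphenyl is the first group at this place to give a readable value. The change reads as an at least 1.5-fold lower number from compound 2 to compound 3 (0.20 log units; that floor lies within the scatter), and the comparison with the bromo compound as an at least 1.5-fold lower number from compound 1 to compound 3 (0.20 log units; that floor lies within the scatter), so a real difference is possible but not established. The other two values remain limits: the limit of > 10000 nM in this assay, at which 2 of the 3 values shown sit.

As far as these compounds go, the true distance of compound 1 and compound 2 from compound 3 stays open. So does what 4-bromophenyl or 4-aminophenyl would give at this place.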